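The compounds below may be only part of what the source reports. "The series", "measured", "known", "first", "only" and "open" are said of these compounds alone.

Compound 1 `CC(C)(C)Sc1c(CC(C)(C)C(=O)O)n(Cc2ccc(Cl)cc2)c2ccc(OCc3ccc4cccnc4n3)cc12`; compound 2 `CC(C)(C)Sc1c(CC(C)(C)C(=O)O)n(Cc2ccc(Cl)cc2)c2ccc(OCc3nc4ccccc4s3)cc12`; compound 3 `CC(COc1ccc2c(c1)c(SC(C)(C)C)c(CC(C)(C)C(=O)O)n2Cc1ccc(Cl)cc1)c1ccccn1`.

In a functional assay (blood) for inhibition, with Homo sapiens as the target (a higher number here means a weaker inhibitor, a lower number a stronger inhibitor), compound 1 gives only a limit, > 3000 nM. In this assay compound 2 gives 260 nM, and compound 3 gives 270 nM, so compound 2 and compound 3 sit within the scatter of each other, with compound 2 holding a number and not a limit. Compound 4 `CC(C)(C)Sc1c(CC(C)(C)C(=O)O)n(Cc2ccc(Cl)cc2)c2ccc(OCc3cccs3)cc12` differs from compound 2 by thiophen-2-yl in place of 1,3-benzothiazol-2-yl on a saturated chain carbon bound to an oxygen on an aromatic ring. The measured steps that bear on this position are an at least 11-fold lower number from compound 1 to compound 2 (1.06 log units; beyond the scatter) and an at least 11-fold lower number from compound 1 to compound 3 (1.04 log units; beyond the scatter), while a 1.0-fold higher number from compound 2 to compound 3 (0.02 log units; within the scatter) shows that quite different groups on that carbon can give the same result. Thiophen-2-yl has no measured counterpart here, so the step of a 1.9-fold higher number from compound 2 to compound 4 (0.28 log units; within the scatter) is expected to be modest and uncertain in direction. Compound 4 is estimated at 500 nM, within 150 nM to 2000 nM.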

Compound 4, half-maximal inhibitory concentration: > 3000 nM
Compound 4 gave a limit, no number (the forecaster's own chance of this, stated with the estimate: 15%); middle value at least 6.0-fold (0.77 log units) from the limit.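

Thiophen-2-yl on this saturated chain carbon does not keep the result shared by compound 2 and compound 3, giving an at least 11-fold higher number from compound 2 to compound 4 (1.06 log units; beyond the scatter) and an at least 11-fold higher number from compound 3 to compound 4 (1.04 log units; beyond the scatter). Compound 4 gives only a limit, as compound 1 does, and this is the limit of this assay: the limit of > 3000 nM in this assay, at which 2 of the 4 values shown sit. The group of compound 4 is smaller and that of compound 1 larger than those of compound 2 and compound 3, so group size alone does not sort these four.

The step from compound 1 to compound 4 cannot be read, as both values are limits. As far as these compounds go, whether a 1,3-thiazol-2-yl or a plain phenyl on that carbon would track compound 2 or compound 4 stays open.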